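A few compounds are considered here, and "the series" means these few. Any claim that something is new, unique, unknown or untested is made for them only; others in the source may bear on it.

Three compounds share one core, an aminonaphthoquinone linked through a short chain to a sulfonyl-bearing amidine, and differ only in the group on the amine nitrogen. Compound 1 `Cc1ccc(S(=O)(=O)/N=C(/CCNC2=CC(=O)c3ccccc3C2=O)Nc2ccc(F)cc2)cc1` carries a 4-fluorophenyl there and in a functional assay on MCF7 cells (Homo sapiens) for cytotoxicity, read by MTT assay, with a stated time of 48 h (on this read-out higher numbers stand for weaker inhibition and lower numbers for stronger inhibition), compound 1 gives 4260 nM. Compound 2 `COc1ccc(N/C(CCNC2=CC(=O)c3ccccc3C2=O)=N\S(=O)(=O)c2ccc(C)cc2)c(OC)c1` carries a 2,4-dimethoxyphenyl and in this assay compound 2 gives 30200 nM. Compound 3 `Cc1ccc(S(=O)(=O)/N=C(/CCNC2=CC(=O)c3ccccc3C2=O)Nc2cc(F)c(F)c(F)c2)cc1` carries a 3,4,5-trifluorophenyl and in this assay compound 3 gives 6610 nM, the second highest of the three numbers; the step of a 1.6-fold higher number from compound 1 to compound 3 (0.19 log units; within the scatter) lies within the scatter, whereas a 4.6-fold lower number from compound 2 to compound 3 (0.66 log units; beyond the scatter) and a 7.1-fold higher number from compound 1 to compound 2 (0.85 log units; beyond the scatter) are modest but real.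

Compound 4 `Cc1ccc(S(=O)(=O)/N=C(/CCNC2=CC(=O)c3ccccc3C2=O)NCc2ccccc2)cc1` changes the group on the amine nitrogen once more: benzyl in place of 3,4,5-trifluorophenyl on an amine nitrogen. Going by the values given here, no measured step swaps an aromatic ring for a benzyl, so the three aryl-to-aryl steps are the only guide, and they span from within the scatter to a modest shift. The expectation is therefore a small step, a 1.2-fold higher number from compound 3 to compound 4 (0.08 log units; within the scatter), with compound 4 estimated at 8000 nM in this assay, within a range from 2500 nM to 25000 nM.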

Compound 4, half-maximal inhibitory concentration: 3630 nM
Estimate against measurement, compound 4: 2.2-fold (0.34 log units) above; measured number inside the range.
By their numbers in this assay, from the lowest: compounds 4, 1 and 3 (each within the scatter of the next); then compound 2.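

Going by these compounds alone, compound 4 is the first compound here with benzyl rather than a fluorinated or methoxylated phenyl on the amine nitrogen, and in this assay both a 1.8-fold lower number from compound 3 to compound 4 (0.26 log units; within the scatter) and a 1.2-fold lower number from compound 1 to compound 4 (0.07 log units; within the scatter) stay within the scatter. Among these compounds, then, fluorine on the group is not required for a number in this range, and compound 2 alone stands apart, with an 8.3-fold lower number from compound 2 to compound 4 (0.92 log units; beyond the scatter) being modest but real. No supporting measurement bears on why the numbers fall this way.

The compounds shown leave open how a longer chain such as phenethyl, or a small alkyl group such as methyl, would behave on this nitrogen. They also leave open whether a phenyl ring carrying a single methoxy group, or an amine or carboxylic acid, would track compound 2 or the other three.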